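Methoxy for Fluoro on a Bis-indole Scaffold

The source may report more compounds than this note shows. Statements on the series, on what has been measured and on what is new or still open speak of the compounds shown alone.

Measured compounds:
Compound 1 `N#C/C(=C\c1c[nH]c2cc(F)ccc12)C(=O)c1c[nH]c2ccccc12`, in a functional assay on PC-3 cells (Homo sapiens) for cytotoxicity, read by WST assay, with a stated time of 24 h; on this read-out lower numbers stand for stronger inhibition and higher numbers for weaker inhibition: > 50000 nM, a limit of the assay.
Compound 2 `COc1ccc2c(/C=C(\C#N)C(=O)c3c[nH]c4ccccc34)c[nH]c2c1`, in this assay: 33300 nM.
Compound 3 `COc1ccc2[nH]cc(/C=C(\C#N)C(=O)c3c[nH]c4cc(F)ccc34)c2c1`, in this assay: > 50000 nM, a limit of the assay.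

The change from compound 1 to compound 2 is methoxy in place of fluoro on an aromatic carbon. It produced an at least 1.5-fold lower number from compound 1 to compound 2 (0.17 log units; that floor lies within the scatter); that floor rests on (the limit of > 50000 nM in this assay, at which 2 of the 3 values shown sit). Compound 4 `COc1ccc2c(C(=O)/C(C#N)=C/c3c[nH]c4ccc(OC)cc34)c[nH]c2c1` is not yet measured in this assay. It arises from compound 3 by methoxy in place of fluoro on an aromatic carbon, the same change at the same place. How the core of compound 3 differs from the core of compound 1 is not broken down here. Compound 3 itself returned only a limit, > 50000 nM. The expected step is an at least 1.2-fold lower number from compound 3 to compound 4 (0.09 log units; that floor lies within the scatter), resting on the measured at least 1.5-fold lower number from compound 1 to compound 2 (0.17 log units; that floor lies within the scatter). Compound 4 is therefore estimated at 40000 nM, likely between 20000 nM and 80000 nM, with a fair chance that only a limit is reported.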

Compound 4, half-maximal inhibitory concentration: 31100 nM
Estimate against measurement, compound 4: 1.3-fold (0.11 log units) above; the range from low to high includes it.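

In this assay, methoxy in place of fluoro on an aromatic carbon gave an at least 1.6-fold lower number from compound 3 to compound 4 (0.20 log units; that floor lies within the scatter). Both steps are floors that lie within the scatter, so the two cores neither show that the change carries over with a fixed size nor show that it fails to carry over: the same change on two cores in this assay, an at least 1.5-fold lower number (0.17 log units; that floor lies within the scatter) from compound 1 to compound 2 and an at least 1.6-fold lower number (0.20 log units; that floor lies within the scatter) from compound 3 to compound 4; the limit leaves it open whether they differ. Each floor is also tied to a limit of the assay rather than to a number: the limit of > 50000 nM in this assay, at which 2 of the 4 values shown sit.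

The compounds shown leave open how large the step is on a core whose fluoro compound returns a number rather than a limit. They also leave open what an amine or a carboxylic acid on that aromatic carbon would give in this assay.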